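The source may report more compounds than this note shows. Statements on the series, on what has been measured and on what is new or still open speak of the compounds shown alone.

Of the compounds shown here, three of a shared core have been measured so far in an ADME assay on S9 fraction from liver (Mus musculus, strain ICR/CD-1) for metabolic stability, read by LC-MS, using NADPH, with a stated time of 5 min, tested at 2 uM; on this read-out higher numbers stand for a longer-lived compound and lower numbers for a shorter-lived compound. Compound 1 `CC1CCN(C2CCN(S(=O)(=O)c3cccc(-c4ccccc4C(F)(F)F)c3)CC2)CC1` gives 0.617 h, compound 2 `CC1CCN(C2CCN(S(=O)(=O)c3ccc(Cl)c(Cl)c3)CC2)CC1` gives 0.55 h, and compound 3 `CC1CCN(C2CCN(S(=O)(=O)c3cccc(-c4ccccc4)c3)CC2)CC1` gives 0.517 h. For the measured compounds named here, the one step among them that changes a single place, hydrogen in place of trifluoromethyl on an aromatic carbon, is a 1.2-fold lower number from compound 1 to compound 3 (0.08 log units; within the scatter). Compound 2 stands alongside the other two: its gap to compound 3 and its gap to compound 1 are both within the scatter, so the three numbers cannot be told apart.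

Compound 4 `CC1CCN(C2CCN(S(=O)(=O)c3ccccc3Br)CC2)CC1` differs from compound 2 by 2-bromophenyl in place of 3,4-dichlorophenyl on a sulfonyl sulfur. Going by the values given here, no measured step exchanges one aryl group for another on the sulfonyl sulfur, so nothing bears directly on this change; the only step at hand, from compound 1 to compound 3, stayed within the scatter, and the three measured numbers are all close. On that footing no step beyond the scatter is expected in this assay, in either direction. For compound 4 the estimate is 0.55 h, with a range from 0.3 h to 1 h, which means an expected step of no change at the digits printed from compound 2 to compound 4 (within the scatter).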

Compound 4, half-life: 0.1 h
Beside the measured number, compound 4's estimate is 5.5-fold (0.74 log units) above it; the measured number lies below the stated range.
By their numbers in this assay, from the lowest: compound 4; then compounds 3, 2 and 1 (each within the scatter of the next).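

In this assay, the exchange of 2-bromophenyl for 3,4-dichlorophenyl on the sulfonyl sulfur gives a 5.5-fold lower number from compound 2 to compound 4 (0.74 log units; beyond the scatter), so the half-life does respond to the aryl group at this place. For the compounds shown here, the one earlier step, a change within the aryl group carried by compound 1, stayed within the scatter and gave no sign of this. No measurement shown here accounts for the step.

The change alters the kind of halogen, their number and where they sit on the ring all at once, and the compounds shown do not separate these. On these data alone, it also remains open how an unsubstituted phenyl on the sulfonyl sulfur, or an aryl group carrying a nitrile or a methoxy group instead of halogen, would fare in this assay.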